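Fused lactam series: N-substituent removal at compound 3

The source may hold more compounds than are shown below. What is called first, only, known or untested is meant among the compounds shown, and "the series" means these compounds.

Measured compounds in a functional assay on HeLa cells (Homo sapiens) for antiproliferative activity, read by MTT assay, with a stated time of 72 h; a lower number here means a stronger inhibitor, a higher number a weaker inhibitor:
Compound 1 `O=C1COc2ccc(-c3cnc4ccccc4c3)cc2N1C1CCCCC1` gives 19700 nM
Compound 2 `COc1ncc(-c2ccc3c(c2)N(c2ccc(Cl)cc2)C(=O)CO3)cc1NS(=O)(=O)c1ccc(F)cc1` gives 4830 nM
Compound 3 `O=C1COc2ccc(-c3cccc(NS(=O)(=O)c4ccc(F)cc4)c3)cc2N1c1ccc(Cl)cc1` gives 35000 nM

Compound 3 carries the highest number of the three in this assay. Its gap to compound 1 lies within the scatter, so the two cannot be ordered; its gap to compound 2, with a different aryl group on the shared core, is beyond the scatter, and compound 2 shows the lower number. Among the measured compounds shown here, no step between two measured compounds that differ in one place is available.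

Compound 4 `O=C1COc2ccc(-c3cccc(NS(=O)(=O)c4ccc(F)cc4)c3)cc2N1` is the unmeasured analogue of compound 3. The change is hydrogen in place of 4-chlorophenyl on an amide-type nitrogen in a ring. For the measured compounds named here, no measured pair shows the effect of removing a group from this amide-type nitrogen, so the direction rests on compound 3 alone, which already stands at the weak end of the set with 35000 nM. The expected step is a 1.4-fold higher number from compound 3 to compound 4 (0.15 log units; within the scatter), a small rise in the number or none beyond the scatter; a fall to the level of compound 2 is not expected. Compound 4 is therefore estimated at 50000 nM, within 15000 nM to 150000 nM.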

Compound 4, half-maximal inhibitory concentration: > 40000 nM
Compound 4 gave a limit, no number; the forecaster's own chance of this, stated with the estimate: 30%; the middle value is on the limit's open side.
By their numbers in this assay, from the lowest: compound 2; then compounds 1 and 3 (each within the scatter of the next). At a limit, above all of these: compound 4.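

In this assay compound 4 gives > 40000 nM, which is a limit of the assay and not a number. Among the compounds shown here, the step is an at least 1.1-fold higher number from compound 3 to compound 4 (0.05 log units; that floor lies within the scatter), so this gives the only one-place reading at the amide-type nitrogen in a ring: replacing 4-chlorophenyl with hydrogen brings no fall in the number, while the floor of the step does not establish a rise. The size of any rise stays unread because compound 4 stands at a limit: the limit of > 40000 nM in this assay, at which 1 of the 4 values shown sits.

Only 4-chlorophenyl and hydrogen on this nitrogen can be compared directly, as the cyclohexyl group of compound 1 sits on a compound that also differs elsewhere. Open, going by these compounds, is whether a methyl group, a short chain ending in an amine or a benzyl group at this nitrogen would lower the number on the core of compound 3.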